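A Bromo-to-Ethoxy Swap on a Shared Urea Core

A few compounds are considered here, and "the series" means these few. Any claim that something is new, unique, unknown or untested is made for them only; others in the source may bear on it.

Of the compounds shown here, two built on one shared core have been measured so far. Compound 1 `Cc1nc2ccccc2c(=O)n1NC(=O)Nc1ccc(I)cc1` and compound 2 `Cc1nc2ccccc2c(=O)n1NC(=O)Nc1ccc(Br)cc1` differ only in the halogen on the outer aromatic ring. In a functional assay on the whole organism for inhibition, with Mus musculus as the target, with a stated time of 1 h, at a dose of 100 mg/kg by the intraperitoneal route (a lower number here means less inhibition, a higher number more inhibition at the dose given (going by the name of the read-out)), compound 1 gives 53%, and compound 2 gives 51%. The step of a number 2 percentage points lower from compound 1 to compound 2 (within the scatter) is small, so compound 2 stands alongside compound 1, the two numbers not distinguishable within the usual scatter.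

Compound 3 `CCOc1ccc(NC(=O)Nn2c(C)nc3ccccc3c2=O)cc1` has not yet been tested. It differs from compound 2 in one place: ethoxy in place of bromo on an aromatic carbon. Going by the values given here, only the step from compound 1 to compound 2 bears on this change, and it exchanged one halogen for another, which says little about an ethoxy entering. With no better guide, the step from compound 2 to compound 3 is expected to be a number 1 percentage points lower from compound 2 to compound 3 (within the scatter), with no direction beyond the scatter. Compound 3 is therefore estimated to give 50% in this assay, between 30% and 70%.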

Compound 3, a percentage reported as inhibition, in the whole organism at one dose (the size of the read-out at that dose, not a potency): 45%
Compound 3: middle estimate off by 5 percentage points, on the high side; the range from low to high includes it.
By their numbers in this assay, from the lowest: compounds 3, 2 and 1 (each within the scatter of the next).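

In this assay, an ethoxy group, which brings an oxygen and a hydrogen-bond acceptor, can stand at this place on the outer ring without a step beyond the scatter: the change gives a number 6 percentage points lower from compound 2 to compound 3 (within the scatter) and, with ethoxy replacing iodo, a number 8 percentage points lower from compound 1 to compound 3 (within the scatter) as well. The earlier step only exchanged one halogen for another, whereas this result shows that a group other than a halogen, on an aromatic carbon para to a large group, also stays within the scatter. No measurement shown offers a reason for these numbers.

Going by these compounds, whether the position accepts groups of other kinds stays open: an amine, a carboxylic acid or a longer chain such as butoxy might move the read-out beyond the scatter or leave it unchanged. With a single dose, these numbers also leave potency open.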